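Cytotoxicity notes on three measured analogues and one pending

A few compounds are considered here, and "the series" means these few. Any claim that something is new, unique, unknown or untested is made for them only; others in the source may bear on it.

Compound 1 `CCC1(Cc2ccccc2)OS(=O)(=O)C=C1OCc1ccc(C)cc1` gives >= 16000 nM in an ADME assay on HEL cells (Homo sapiens) for cytotoxicity, with a stated time of 3 days (a higher number here means that more compound is tolerated, a lower number that less compound is tolerated), a limit of the assay.
Compound 2 `CCC1(Cc2ccccc2)OS(=O)(=O)C=C1OC` gives > 400000 nM in this assay, again a limit.
Compound 3 `CCC1(Cc2ccccc2)OS(=O)(=O)C=C1OC(=O)c1ccccc1` gives > 400000 nM in this assay, also a limit.

Compound 3 thus stands at the upper limit of this assay, a position it shares with one other measured compound (the limit of > 400000 nM in this assay, at which 2 of the 3 values shown sit), while compound 1 stops at a lower limit (the limit of >= 16000 nM in this assay, at which 1 of the 3 values shown sits). None of the steps among the measured compounds can be read: a step that the two limits leave unreadable from compound 1 to compound 2; a step that the two limits leave unreadable from compound 1 to compound 3; a step that the two limits leave unreadable from compound 2 to compound 3.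

Compound 4 `CCC1(Cc2ccccc2)OS(=O)(=O)C=C1OCC1CCCCC1` differs from compound 3 as follows: cyclohexylmethyl in place of benzoyl on an oxygen on an unsaturated carbon. The steps from compound 1 to compound 3 and from compound 2 to compound 3 change the same oxygen on an unsaturated carbon, but both are unreadable, so they set no size for the new step. No direction is therefore expected beyond the scatter, and compound 4 is expected most likely to end at a limit as well.

Compound 4 is estimated at 150000 nM, within 16000 nM to 400000 nM. This estimate corresponds to an expected step of an at least 2.6-fold lower number from compound 3 to compound 4 (0.42 log units; beyond the scatter).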

Compound 4, minimum cytotoxic concentration: >= 200000 nM
Compound 4: no number, only a limit; the forecaster's own chance of this, stated with the estimate: 65%; at least 1.3-fold (0.12 log units) between middle value and limit.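

Compound 4 also ends at a limit in this assay, so its steps from compound 1, compound 2 and compound 3 cannot be read. With only limits in hand, the compounds shown leave open whether any change on the oxygen on an unsaturated carbon shifts the tolerated concentration, and by how much.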